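Moving the methoxy group on the shared aryl ring

A few compounds are considered here, and "the series" means these few. Any claim that something is new, unique, unknown or untested is made for them only; others in the source may bear on it.

Compound 1, `CCO/N=C(\CCN1CCN(c2ccccc2)CC1)c1ccccc1`: 80%
Compound 2, `CCO/N=C(\CCN1CCN(c2ccccc2OC)CC1)c1ccccc1`: 76%

In a functional assay on HEK293 cells with D(4) dopamine receptor (Homo sapiens) as the target, read by FLIPR (on this read-out lower numbers stand for smaller maximal responses and higher numbers for larger maximal responses), compound 1 gives 80% and compound 2 gives 76%. Going by the values given here, the one measured step, a number 4 percentage points lower from compound 1 to compound 2 (within the scatter), keeps the two within the usual scatter, so compound 2 stands within the scatter of compound 1 on these numbers. Compound 3, `CCO/N=C(\CCN1CCN(c2ccc(OC)cc2)CC1)c1ccccc1`, differs from compound 2 by 4-methoxyphenyl in place of 2-methoxyphenyl on an amine nitrogen in a ring. Among the compounds with values here, no measured step moves a methoxy group from one place on the ring to another; the only known step, a number 4 percentage points lower from compound 1 to compound 2 (within the scatter), adds one and stays within the scatter. Compound 3 is therefore expected to show no step beyond the scatter, a number 1 percentage points lower from compound 2 to compound 3 (within the scatter). The estimate for compound 3 is 75%, between 55% and 95%.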

Compound 3, largest response reached (reported as efficacy), in percent of the reference or control that the assay uses: 5%
Estimate against measurement, compound 3: 70 percentage points above; measured number outside the range, below it.
By their numbers in this assay, from the lowest: compound 3; then compounds 2 and 1 (each within the scatter of the next).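

In this assay, the place of the methoxy group on the aryl ring matters greatly: 4-methoxyphenyl in place of 2-methoxyphenyl on an amine nitrogen in a ring, with the same atoms, gives a large step (a number 71 percentage points lower from compound 2 to compound 3 (beyond the scatter)). The addition of methoxy to the unsubstituted phenyl is thus not harmless in every place, since as 4-methoxyphenyl it also gives a large step (a number 75 percentage points lower from compound 1 to compound 3 (beyond the scatter)). Nothing available explains this loss of response. The compounds shown leave open whether methoxy itself is required, as 4-ethoxyphenyl, 4-chlorophenyl or 4-hydroxyphenyl in the same place could show.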